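The source may hold more compounds than are shown below. What is called first, only, known or untested is meant among the compounds shown, and "the series" means these compounds.

In an ADME assay on liver for metabolic stability, with Liver microsome (Homo sapiens) as the target, read by LC-MS, using microsomes (a higher number here means faster removal of the compound, a lower number slower removal), compound 1 (`O=C(NCc1cc(Cl)ccc1-n1cnnn1)[C@@H]1C[C@@H]2C[C@@H]2N1C(=O)[C@H](O)c1cccc(Cl)c1`) gives > 500 mL.min-1.g-1, which is a limit and not a number. Compound 2 (`O=C(NCc1cc(Cl)ccc1-n1cnnn1)[C@@H]1CCON1C(=O)[C@H](O)c1ccccc1`) gives < 12 mL.min-1.g-1, also a limit. Of these two values, compound 1 stands at the fast-removal end. Compound 3 (`CC(C)(C)[C@@H](O)C(=O)N1[C@H](C(=O)NCc2cc(Cl)ccc2-n2cnnn2)C[C@@H]2C[C@@H]21`) keeps the core of compound 1 and changes one group: tert-butyl in place of 3-chlorophenyl on a saturated chain carbon bound to a carbonyl carbon and an oxygen on a saturated carbon. Among the measured compounds shown here, no measured step covers this change, so the expectation is loose. Compound 1 stands at > 500 mL.min-1.g-1, a limit, which leaves room in one direction only, towards slower removal. The expected step is an at least 2.5-fold lower number from compound 1 to compound 3 (0.39 log units; beyond the scatter). For compound 3 the estimate is 200 mL.min-1.g-1, with an expected range of 50 mL.min-1.g-1 to 500 mL.min-1.g-1.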

Compound 3, intrinsic clearance in microsomes: 75 mL.min-1.g-1
Estimate against measurement, compound 3: 2.7-fold (0.43 log units) above, within the range that was stated.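

In this assay, tert-butyl in place of 3-chlorophenyl on a saturated chain carbon bound to a carbonyl carbon and an oxygen on a saturated carbon gives an at least 6.6-fold lower number from compound 1 to compound 3 (0.82 log units; beyond the scatter). Among the compounds shown here, this single change on the core of compound 1 is enough to move the read-out off a limit, and compound 3 holds the only one of the three values shown that is a number. The true size of the step cannot be read because the value of compound 1 is a limit, so the step gives only a minimum: the limit of > 500 mL.min-1.g-1 in this assay, at which 1 of the 3 values shown sits.

Open, from the compounds shown here alone, is how a phenyl without the chlorine, a cyclohexyl or an isopropyl would read at this position on the same core. Compound 2 differs from compound 1 in more than one place, so it cannot show how this change behaves on another core.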